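Fluoro in place of bromo on compound 3

The source may hold more compounds than are shown below. What is called first, only, known or untested is meant among the compounds shown, and "the series" means these compounds.

In an ADME assay on Vero 76 cells (Chlorocebus sabaeus) for cytotoxicity, read by crystal violet staining, with a stated time of 96 h (on this read-out lower numbers stand for higher toxicity in this test and higher numbers for lower toxicity in this test), compound 3 `FC(F)(F)c1cccc(NC(=S)Nc2cccc(Br)c2)c1` reads 14000 nM and sits within the scatter of compound 1 `O=[N+]([O-])c1ccc(NC(=S)Nc2cccc(C(F)(F)F)c2)cc1` at 10000 nM on the numbers shown. Compound 2 `CCNC(=S)Nc1cccc(C(F)(F)F)c1` gives > 100000 nM as its reading, which is a limit and not a number. Compound 4 `Fc1cccc(NC(=S)Nc2cccc(C(F)(F)F)c2)c1` alters compound 3 in a single place, where fluoro in place of bromo on an aromatic carbon is the difference, fluoro in place of bromo on an aromatic carbon. For the measured compounds named here, only one measured step bears on this, and only loosely. The step of an at least 7.1-fold lower number from compound 2 to compound 3 (0.85 log units; beyond the scatter) goes beyond the scatter, but it exchanges ethyl for 3-bromophenyl, a far larger change than the one at hand. Compound 1 carries a different aromatic group, yet its 10000 nM stays within the scatter of compound 3. No step beyond the scatter is therefore expected in this assay for this exchange. The expected move is a 1.1-fold higher number from compound 3 to compound 4 (0.06 log units; within the scatter) and so stays small. Compound 4 is estimated at 16000 nM with an expected range of 7000 nM to 40000 nM for this value.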

Compound 4, half-maximal cytotoxic concentration: 20000 nM
The estimate for compound 4 lay 1.3-fold (0.10 log units) below the measured number; the range from low to high includes it.
By their numbers in this assay, from the lowest: compounds 1, 3 and 4 (each within the scatter of the next). At a limit, above all of these: compound 2.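

In this assay, the exchange of bromo for fluoro on this aromatic carbon gives a 1.4-fold higher number from compound 3 to compound 4 (0.15 log units; within the scatter), so the read-out does not separate these two halogens at this position. The 3-fluorophenyl group in place of ethyl gives an at least 5.0-fold lower number from compound 2 to compound 4 (0.69 log units; beyond the scatter), and this step points the same way as the one for 3-bromophenyl, an at least 7.1-fold lower number from compound 2 to compound 3 (0.85 log units; beyond the scatter), so the lower number does not depend on which of the two halogens is present. Compound 2 stands at a limit and not at a number, which leaves both of these steps as bounds: the limit of > 100000 nM in this assay, at which 1 of the 4 values shown sits.

From the compounds shown here alone, it remains open whether an amine or a carboxylic acid on this aromatic carbon would also stay within the scatter of the two halogens. Also open, going by these compounds, is how a longer chain, such as butyl, in place of ethyl would read.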